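Swapping the benzyl group on a growth-inhibiting core

The source may report more compounds than this note shows. Statements on the series, on what has been measured and on what is new or still open speak of the compounds shown alone.

Among the measured compounds shown here, compound 1 `Nc1cc(N)c2nc(-c3ccccc3)c(NCc3ccc(Cl)c(Cl)c3)nc2c1` is one of three compounds measured in a functional assay on UACC-257 cells (Homo sapiens) for inhibition, read by sulforhodamine B assay, with a stated time of 48 h; on this read-out lower numbers stand for stronger inhibition of growth and higher numbers for weaker inhibition of growth. Compound 1 gives 4570 nM, the lowest number of the three. Compound 2 `CCOC(=O)[C@H](CCC(=O)O)NC(=O)c1ccc(Sc2nc3cc(N)cc(N)c3nc2-c2ccccc2)cc1` gives 17400 nM, and compound 3 `CCOC(=O)[C@H](CCC(=O)O)NC(=O)c1ccc(Oc2nc3cc(N)cc(N)c3nc2-c2ccccc2)cc1` gives 26900 nM; both of these steps from compound 1 lie beyond the usual scatter, so compound 1 is the strongest inhibitor among the measured set. Compounds 2 and 3 differ from compound 1 in more than one place at once, so they give no direct guide to a small exchange on the benzyl group of compound 1.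

Compound 4 `COc1ccc(CNc2nc3cc(N)cc(N)c3nc2-c2ccccc2)cc1` has not been measured. It differs from compound 1 in one place: 4-methoxyphenyl in place of 3,4-dichlorophenyl on a saturated chain carbon bound to a nitrogen on an aromatic ring. For the measured compounds named here, no pair of measured compounds shows this exchange, so its effect in this assay must be estimated rather than read off. The expectation is a modest step in this assay, leaning toward weaker inhibition, and the estimated step is a 1.4-fold higher number from compound 1 to compound 4 (0.15 log units; within the scatter), a change that may well stay within the scatter. Compound 4 is therefore expected to give about 6500 nM in this assay, within a range from 2000 nM to 20000 nM.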

Compound 4, concentration for 50% growth inhibition: 16200 nM
Estimate against measurement, compound 4: 2.5-fold (0.40 log units) below; low and high end bracket the measured number.
By their numbers in this assay, from the lowest: compound 1; then compounds 4, 2 and 3 (each within the scatter of the next).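

Among the compounds shown here, this is the only direct reading of the benzyl position on the shared core: in this assay, exchanging 3,4-dichlorobenzyl for 4-methoxybenzyl gives a 3.5-fold higher number from compound 1 to compound 4 (0.55 log units; beyond the scatter), a step larger than repeated measurements would usually produce. The group on this saturated chain carbon bound to a nitrogen on an aromatic ring therefore matters to the read-out, even though the number of heavy atoms stays the same and both groups hold a six-membered aromatic ring of carbon only. Chlorine leaves, oxygen enters and a hydrogen-bond acceptor is gained, but nothing in the data explains the size of the step.

Removing the chlorines and adding the methoxy group happen together in this one step, and the compounds shown cannot separate their shares. As far as these compounds go, whether a plain benzyl group, a 4-chlorobenzyl group or a benzyl group carrying a carboxylic acid would give a number closer to that of compound 1 or to that of compound 4 remains open.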